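The source may hold more compounds than are shown below. What is called first, only, known or untested is meant among the compounds shown, and "the series" means these compounds.

Working notes on the series. The shared core carries a hydroxy group and a benzyl or phenethyl arm; compound 1 `Oc1c(CCc2ccccc2)ccc2ccccc12`, compound 2 `COc1c(Cc2ccccc2)ccc2ccccc12` and compound 3 `Oc1c(Cc2ccccc2)cc(-c2ccccc2)c2ccccc12` have been tested in an assay on RBL-1 cells with Polyunsaturated fatty acid 5-lipoxygenase (Rattus norvegicus) as the target; a higher number here means a weaker inhibitor, a lower number a stronger inhibitor. Compound 1 gives 140 nM, compound 2 gives 55000 nM, and compound 3 gives 56 nM. Compound 3 thus stands at the lowest number of the three: the number of compound 1 is the nearest and lies beyond the scatter above it, while the number of compound 2, which carries a methoxy group in place of the hydroxy group, lies far beyond the scatter above both.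

Compound 4 `NS(=O)(=O)c1cc(Cc2ccccc2)c(O)c2ccccc12` is not yet measured in this assay. It differs from compound 3 in one place: sulfamoyl in place of phenyl on an aromatic carbon. Among the measured compounds shown here, no step between measured compounds covers this exchange, so the direction of the change rests on the hydroxy group being retained and the phenyl group being lost, and on compound 1 without a phenyl group giving 140 nM. A weakening step from compound 3 to compound 4 of moderate size, a 4.5-fold higher number from compound 3 to compound 4 (0.65 log units; beyond the scatter), is expected. Compound 4 is estimated at 250 nM, within 60 nM to 1500 nM.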

Compound 4, half-maximal inhibitory concentration: 9400 nM
Beside the measured number, compound 4's estimate is 38-fold (1.58 log units) below it, outside the stated range (above it).
By their numbers in this assay, from the lowest: compound 3; then compound 1; then compound 4; then compound 2.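

In this assay, among the compounds shown here, the position para to a hydroxy group proves sensitive to what it carries: sulfamoyl in place of phenyl on an aromatic carbon gives a 170-fold higher number from compound 3 to compound 4 (2.22 log units; beyond the scatter), a large step and the first exchange that can be read directly at this position. The hydroxy group and the benzyl group are the same in both compounds, so the whole step belongs to this single exchange, in which a six-membered aromatic ring of carbon only leaves and a group with no ring, carrying a hydrogen-bond donor and hydrogen-bond acceptors, enters. No measurement at hand accounts for the size of the step, and the pair alone cannot separate the loss of phenyl from the arrival of sulfamoyl.

On these data alone, it remains open whether a methyl group, a chlorine atom, an amine or a carboxylic acid at this place would give a number closer to that of compound 3 or of compound 4. As far as these compounds go, it is equally open whether the sulfamoyl exchange would give a step of similar size with a phenethyl arm in place of the benzyl group.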